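Pyridin-2-yl to piperidin-1-yl at the end of the propyl chain

The source may report more compounds than this note shows. Statements on the series, on what has been measured and on what is new or still open speak of the compounds shown alone.

Three compounds built on a shared core were examined in a functional assay on HCT-116 cells (Homo sapiens) for cytotoxicity; on this read-out lower numbers stand for an effect already at smaller amounts and higher numbers for an effect only at larger amounts of compound. Compound 1 `COCCCOc1ccc(S(=O)(=O)Nc2ccc(C(=O)CSC(C)=O)cn2)cc1` carries a short ether chain and in this assay gives 5300 nM. Compound 2 `CC(=O)SCC(=O)c1ccc(NS(=O)(=O)c2ccc(OCCCc3ccccn3)cc2)nc1` ends its chain in a pyridin-2-yl group, but in this assay compound 2 is recorded as "not determined" (no result reported), so it stands without a value of its own and offers no anchor. Compound 3 `CC(=O)SCC(=O)c1ccc(NS(=O)(=O)c2ccc(OCCCN3CCCCC3)cc2)nc1` is the next variation, and the difference is piperidin-1-yl in place of pyridin-2-yl on a saturated chain carbon, three bonds along the chain from an oxygen on an aromatic ring: a six-membered aromatic ring with one hetero atom is exchanged for a six-membered non-aromatic ring with one hetero atom, at the same place on the chain. Within the data shown here, no measured pair shows what such a change does here, so no size or direction can be drawn from the data, and the only reference point remains compound 1. The value of compound 3 in this assay is therefore estimated near 5000 nM, with a wide range from 1000 nM to 25000 nM.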

Compound 3, half-maximal effective concentration: 1000 nM
Compound 3: middle estimate off by 5.0-fold (0.70 log units), on the high side; the range from low to high includes it.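

In this assay, placing piperidin-1-yl instead of methoxy on a saturated chain carbon, three bonds along the chain from an oxygen on an aromatic ring, gives a 5.3-fold lower number from compound 1 to compound 3 (0.72 log units; beyond the scatter), so this position accepts a six-membered non-aromatic ring and responds to the change with an effect at smaller amounts of compound. Going by these compounds, with no value for compound 2, the exchange of pyridin-2-yl for piperidin-1-yl cannot be read, and its size and direction remain unknown. No measurement at hand explains why the number falls. The compounds shown leave open whether the ring itself or its nitrogen goes with the lower number, which a cyclohexyl group or a dimethylamino group in the same place could help separate. They also leave open how morpholin-4-yl or a longer chain would read out at this position.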